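Chloro on the phenyl of compound 3

This account rests on a few compounds, and the source may have more. Where it says the series, first, only, none or still open, it means among the compounds named here.

In a functional assay on T47D cells (Homo sapiens) for inhibition, with a stated time of 48 h (a lower number here means a stronger inhibitor of growth, a higher number a weaker inhibitor of growth), compound 1 `COc1ccccc1/C=C/C(=O)c1c(O)cc2occc2c1OC` gives 55900 nM and compound 2 `COc1c(C(=O)/C=C/c2ccc(Cl)cc2)c(O)c(Br)c2occc12` gives 3380 nM while compound 3 `C=CCc1c(O)c(C(=O)/C=C/c2ccccc2)c(OC)c2ccoc12` gives 4110 nM on the same read-out. Compound 3 therefore stands within the scatter of compound 2 and, beyond the scatter, far under compound 1.

The next analogue is compound 4 `C=CCc1c(O)c(C(=O)/C=C/c2ccc(Cl)cc2)c(OC)c2ccoc12` which carries chloro in place of hydrogen on an aromatic carbon, para to a large group, so that phenyl becomes 4-chlorophenyl (chloro in place of hydrogen on an aromatic carbon).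

Among the compounds with values here, no two measured compounds differ in one place, so the series gives no direct measure of this change. Compound 2 already holds a 4-chlorophenyl and reads 3380 nM in this assay but it also differs from compound 3 elsewhere, which makes it weak support.

A small step toward a lower number is expected in this assay and is estimated as a 1.4-fold lower number from compound 3 to compound 4 (0.14 log units; within the scatter) without clearly leaving the scatter. The estimate for compound 4 is 3000 nM with an expected range from 1200 nM to 7500 nM for this measurement.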

Compound 4, concentration for 50% growth inhibition: 3290 nM
Compound 4: the middle estimate sits 1.1-fold (0.04 log units) below what was measured, within the range that was stated.
By their numbers in this assay, from the lowest: compounds 4, 2 and 3 (each within the scatter of the next); then compound 1.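

In this assay, within the data shown here, chloro in place of hydrogen on an aromatic carbon, para to a large group, gives a 1.2-fold lower number from compound 3 to compound 4 (0.10 log units; within the scatter) and so provides the first direct reading of the change from phenyl to 4-chlorophenyl: a single chlorine at this position does not move the number beyond the scatter. With 4-chlorophenyl present in both compounds, allyl in place of bromo on an aromatic carbon gives a 1.0-fold lower number from compound 2 to compound 4 (0.01 log units; within the scatter) and likewise stays within the scatter. No measurement is available that could explain either result.

From the compounds shown here alone, it remains open whether an amine, a carboxylic acid or trifluoromethyl in place of chloro at this position would give a step beyond the scatter. Also open, going by these compounds, is whether a longer chain in place of allyl would leave the number within the scatter of compound 4.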